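The compounds below may be only part of what the source reports. "The series", "measured", "known", "first", "only" and "open" are said of these compounds alone.

For the measured compounds named here, in a functional assay on cells (Endothelial cell, Bos taurus) for antiproliferative activity (a higher number here means a weaker inhibitor, a lower number a stronger inhibitor), compound 2 `COc1ccc(/C(F)=C\c2cc(OC)c(OC)c(OC)c2)cc1[N+](=O)[O-]` gives 329000 nM, the higher of the two exact numbers so far. Compound 1 `COc1ccc(/C(F)=C/c2cc(OC)c(OC)c(OC)c2)cc1O` gives a lower number, 26600 nM. Compound 3 `COc1ccc(/C(F)=C/c2cc(OC)c(OC)c(OC)c2)cc1[N+](=O)[O-]` gives > 3000000 nM, and this is a limit of the assay. Compound 4 `COc1ccc(/C(F)=C\c2cc(OC)c(OC)c(OC)c2)cc1F` is still unmeasured and differs from compound 2 in one place: fluoro in place of nitro on an aromatic carbon, in words fluoro in place of nitro on an aromatic carbon. Going by the values given here, no measured step makes this exact swap. The nearest is the step of an at least 110-fold higher number from compound 1 to compound 3 (2.05 log units; beyond the scatter), where nitro replaces hydroxy. Read backwards, it ties losing the nitro to a lower number, but its size rests on (the limit of > 3000000 nM in this assay, at which 1 of the 3 values shown sits). That pair also has the other double-bond configuration as drawn, and the step of an at least 9.1-fold higher number from compound 2 to compound 3 (0.95 log units; beyond the scatter) comes from the fact that compounds 2 and 3 differ only in the configuration as drawn. Since fluoro, not hydroxy, enters here, only part of that large step is carried over. A moderate fall is expected, with the estimated step of a 5.5-fold lower number from compound 2 to compound 4 (0.74 log units; beyond the scatter). For compound 4 the expected value is 60000 nM, within an estimated range of 10000 nM to 300000 nM.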

Compound 4, half-maximal inhibitory concentration: 23000 nM
Compound 4: middle estimate off by 2.6-fold (0.42 log units), on the high side, within the range that was stated.
By their numbers in this assay, from the lowest: compounds 4 and 1 (each within the scatter of the next); then compound 2. At a limit, above all of these: compound 3.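

In this assay the exchange of nitro for fluoro on this aromatic carbon, ortho to a methoxy group, gives a 14-fold lower number from compound 2 to compound 4 (1.16 log units; beyond the scatter). Because both ends of this step are exact numbers, it gives a size for losing the nitro group that the earlier nitro step could not, since that step was drawn with the other double-bond configuration and ended at a limit: the limit of > 3000000 nM in this assay, at which 1 of the 4 values shown sits. A lower number on leaving nitro behind now appears with both configurations as drawn, though with hydroxy as the replacement in one and fluoro in the other.

The compounds shown leave open how an amine, a chloro group or a methyl group would compare at this position. They also leave open what fluoro would give with the other double-bond configuration.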